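A few compounds are considered here, and "the series" means these few. Any claim that something is new, unique, unknown or untested is made for them only; others in the source may bear on it.

Among the compounds with values here, compound 2 `Cc1ccc(-n2nccn2)c(C(=O)N2C[C@H](/C=C/c3ccc(F)cn3)CC[C@H]2C)c1` holds the lower of the two numbers measured in an assay on cells for binding affinity to Orexin receptor type 2 (Homo sapiens), read by radioligand binding; a lower number here means a stronger inhibitor, a higher number a weaker inhibitor: compound 2 gives 3 nM, while its only measured neighbour, compound 1 `Cc1ccc(-n2nccn2)c(C(=O)N2C[C@H](C#Cc3cccnc3)CC[C@H]2C)c1`, gives 41 nM in this assay. Within the data shown here, the single step recorded so far, a 14-fold lower number from compound 1 to compound 2 (1.14 log units; beyond the scatter), came from exchanging the group on the saturated ring carbon. Compound 3 `Cc1ccc(-n2nccn2)c(C(=O)N2C[C@H](C#Cc3cncc(CO)c3)CC[C@H]2C)c1` reverses much of that exchange and adds something new: 2-(5-(hydroxymethyl)pyridin-3-yl)ethynyl in place of 2-(5-fluoropyridin-2-yl)ethenyl on a saturated ring carbon. Among the measured compounds shown here, the step from compound 1 to compound 2 is the only one that bears on this case, and it was large; compound 3 restores the triple bond and the pyridin-3-yl attachment seen in compound 1, while the hydroxymethyl group has no measured counterpart here. The expected step is therefore estimated as a 10-fold higher number from compound 2 to compound 3 (1.00 log units; beyond the scatter), a return toward the level of compound 1 rather than beyond it, with the hydroxymethyl group widening the uncertainty. The estimated value for compound 3 in this assay is 30 nM, with a range from 8 nM to 120 nM.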

Compound 3, inhibition constant: 32 nM
Beside the measured number, compound 3's estimate is 1.1-fold (0.03 log units) below it, within the range that was stated.
By their numbers in this assay, from the lowest: compound 2; then compounds 3 and 1 (each within the scatter of the next).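

Putting hydroxymethyl in place of hydrogen on an aromatic carbon of the pyridin-3-yl ring gives a 1.3-fold lower number from compound 1 to compound 3 (0.11 log units; within the scatter) in this assay, so compound 1 and compound 3 cannot be told apart, and this aromatic carbon accepts the added group without a readable shift in the number. The other new step, an 11-fold higher number from compound 2 to compound 3 (1.03 log units; beyond the scatter), is about as large as the earlier 14-fold lower number from compound 1 to compound 2 (1.14 log units; beyond the scatter) read in reverse, so among these three compounds, the two carrying an ethynyl link sit together and compound 2, with its 2-(5-fluoropyridin-2-yl)ethenyl group, stands apart from both. Nothing shown here offers a measured explanation for these numbers.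

The compounds shown leave open which part of the exchange separates compound 2 from the others, since the double bond, the attachment point on the pyridine and the fluorine change together and no compound alters one of them alone. From the compounds shown here alone, it also remains open whether an amine, a carboxylic acid or a longer chain such as 2-hydroxyethyl on the same aromatic carbon would leave the number as unchanged as hydroxymethyl does.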